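The source may report more compounds than this note shows. Statements on the series, on what has been measured and on what is new or still open speak of the compounds shown alone.

Working notes on the series. In a functional assay on HeLa cells (Homo sapiens) for inhibition, with a stated time of 72 h (on this read-out higher numbers stand for an effect only at larger amounts of compound and lower numbers for an effect already at smaller amounts), compound 1 `COc1cc(OCc2cnc(Cl)c(Cl)c2)ccc1CNCc1ccncc1` gives 400 nM and compound 2 `COc1cc(CNCc2ccncc2)ccc1OCc1ccc(C)cc1` gives 5000 nM. Compound 3 `COc1cc(CNc2nc[nH]n2)ccc1OCc1ccc(Cl)nc1` gives 69000 nM in this assay, the highest of the three numbers, beyond the scatter from both neighbours. Compound 4 `COc1cc(CNCCSc2nnnn2C)ccc1OCc1ccc(Cl)nc1` is not yet measured in this assay; compared with compound 3 it carries 2-((1-methyl-1H-tetrazol-5-yl)sulfanyl)ethyl in place of 1H-1,2,4-triazol-3-yl on an amine nitrogen. Among the compounds with values here, no directly comparable step between measured compounds exists here. Compounds 1 and 2, whose amine nitrogen links two saturated chain carbons, give lower numbers than compound 3, so a step downward beyond the scatter is expected from compound 3 to compound 4 of about a 4.6-fold lower number from compound 3 to compound 4 (0.66 log units; beyond the scatter). Compound 4 is therefore estimated at 15000 nM in this assay, within 3000 nM to 70000 nM.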

Compound 4, half-maximal effective concentration: 86000 nM
Compound 4: middle estimate off by 5.7-fold (0.76 log units), on the low side, and the stated range ends below it.
By their numbers in this assay, from the lowest: compound 1; then compound 2; then compounds 3 and 4 (each within the scatter of the next).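

In this assay the change reads as a 1.2-fold higher number from compound 3 to compound 4 (0.10 log units; within the scatter), so on this amine nitrogen 2-((1-methyl-1H-tetrazol-5-yl)sulfanyl)ethyl and 1H-1,2,4-triazol-3-yl cannot be told apart. Within the data shown here, a saturated chain carbon on this nitrogen, carried by the tetrazole-bearing group, therefore does not by itself lower the number in this pair, something the earlier compounds, which differ in more than one place, could not show. No available evidence bears on this result.

From the compounds shown here alone, whether a benzyl group or a plain longer alkyl chain on this amine nitrogen would give a number beyond the scatter from compound 3 remains open.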